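Piperazine aryl swap on the shared core: compound 3

The source may report more compounds than this note shows. Statements on the series, on what has been measured and on what is new or still open speak of the compounds shown alone.

Measured so far:
compound 1, `Cc1ccc(N2CCN(Cn3nc(-c4ccc5c(c4)OCCO5)oc3=S)CC2)c(C)c1`, > 50000 nM
compound 2, `S=c1oc(-c2ccc3c(c2)OCCO3)nn1CN1CCN(c2ccccn2)CC1`, 25100 nM

Compound 1 carries 2,4-dimethylphenyl on the ring nitrogen and in a functional assay on HeLa cells (Homo sapiens) for antiproliferative activity, read by MTT assay, with a stated time of 48 h (a lower number here means a stronger inhibitor, a higher number a weaker inhibitor), compound 1 reaches only > 50000 nM, which is a limit of the assay and not a number (the limit of > 50000 nM in this assay, at which 1 of the 2 values shown sits). For the measured compounds named here, compound 2, with pyridin-2-yl in that place, is the only compound of the pair with a measured number, 25100 nM in this assay. The one step shown, an at least 1.9-fold lower number from compound 1 to compound 2 (0.29 log units; that floor lies within the scatter), runs from a limit and its floor sits within the scatter, so the pair gives no secure direction.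

Compound 3, `S=c1oc(-c2ccc3c(c2)OCCO3)nn1CN1CCN(c2cccc(Cl)c2Cl)CC1`, has not been measured. It differs from compound 2 by 2,3-dichlorophenyl in place of pyridin-2-yl on an amine nitrogen in a ring. Going by the values given here, the change reverts the ring nitrogen substituent to a carbon-only aromatic ring, which is the kind of group compound 1 carries, so the only bearing step is the reverse of an at least 1.9-fold lower number from compound 1 to compound 2 (0.29 log units; that floor lies within the scatter). Since that step was at most a small one, a step back of similar size or none beyond the scatter is expected for a 1.8-fold higher number from compound 2 to compound 3 (0.25 log units; within the scatter). Compound 3 is therefore expected to give about 45000 nM, with a range from 15000 nM to 150000 nM, and a limit read-out is plausible.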

Compound 3, half-maximal inhibitory concentration: > 50000 nM
Compound 3: a limit, no number; the forecaster's own chance of this, stated with the estimate: 50%; at least 1.1-fold (0.04 log units) between middle value and limit.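

In this assay compound 3 gives > 50000 nM, which is a limit of the assay and not a number. For the compounds shown here, at this position on the amine nitrogen in a ring, the change to 2,3-dichlorophenyl gives an at least 1.9-fold higher number from compound 2 to compound 3 (0.29 log units; that floor lies within the scatter); this step runs from the only measured number to a limit, so it sets no secure direction for the swap. The step between the two compounds at the limit cannot be read, but 2,4-dimethylphenyl and 2,3-dichlorophenyl, both carbon-only aromatic rings, now read alike as limits, and pyridin-2-yl alone gives a number: the limit of > 50000 nM in this assay, at which 2 of the 3 values shown sit.

The compounds shown leave open how an unsubstituted phenyl or a pyrimidin-2-yl ring on this nitrogen would read, and whether an acetyl group, with no aromatic ring in this place, would give a number clearly apart from that of compound 2, 25100 nM. The shared core is the same in all three compounds, so its own share in these read-outs cannot be told from them.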